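Dienamide series: removing one methoxy from compound 1

The source may report more compounds than this note shows. Statements on the series, on what has been measured and on what is new or still open speak of the compounds shown alone.

Measured so far in an assay for inhibition of Polyunsaturated fatty acid 5-lipoxygenase (Homo sapiens), read by spectrophotometry, tested at 20 uM; on this read-out lower numbers stand for less inhibition and higher numbers for more inhibition at the one concentration tested (going by the name of the read-out):
compound 1 `COc1ccc(/C=C/C=C/C(=O)N2CCCCC2)cc1OC` gives 51.9%
compound 2 `O=C(/C=C/C=C/C=C/c1ccc(O)c(O)c1)N1CCCCC1` gives 30.3%
compound 3 `CN(C)c1ccc(/C=C/C=C/C=C/C(=O)N2CCCCC2)cc1` gives 27.4%

Compound 1 stands highest of the three numbers in this assay. Its nearest neighbour is compound 2, which reads lower by a margin beyond the scatter, and compound 3 lies further down still, also beyond the scatter. Going by the values given here, no two of the measured compounds differ in only one place, so no single step between them is known, and nothing measured yet isolates the part played by either methoxy group of compound 1.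

Compound 4 `COc1ccc(/C=C/C=C/C(=O)N2CCCCC2)cc1` is not yet measured. It differs from compound 1 as follows: hydrogen in place of methoxy on an aromatic carbon

Among the compounds with values here, no measured pair shows the effect of taking a methoxy group away on this core, so the expectation rests on compound 1 alone and on the general picture that both compounds with other ring substitution, compound 2 and compound 3, read lower than compound 1. A modest drop is expected, reaching a little beyond the scatter, with the step of a number 11.9 percentage points lower from compound 1 to compound 4 (beyond the scatter) as the estimate. Compound 4 is therefore expected to give about 40% in this assay, in the range 22% to 58%.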

Compound 4, a percentage reported as inhibition, at one concentration (the size of the read-out at that concentration, not a potency): 42.6%
Compound 4: the middle estimate sits 2.6 percentage points below what was measured; measured number inside the range.
By their numbers in this assay, from the lowest: compounds 3 and 2 (each within the scatter of the next); then compounds 4 and 1 (each within the scatter of the next).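

In this assay, going by these compounds alone, hydrogen in place of methoxy on this aromatic carbon, ortho to a methoxy group and meta to a large group, gives a number 9.3 percentage points lower from compound 1 to compound 4 (within the scatter), the first comparison that isolates a single place. This methoxy group is therefore not shown to matter for the read-out at the one concentration tested, since compound 1 and compound 4 cannot be told apart within the usual scatter, although a smaller real effect of the change cannot be excluded from this one pair. No supporting data bear on how this result arises.

The compounds shown leave open what part, if any, the methoxy group that remains in compound 4 plays, since no single step on the shared core touches that group. They also leave open whether a different replacement at the same aromatic carbon, such as a chlorine atom, an amine or a carboxylic acid, would move the number beyond the scatter, rather than stay as close to compound 1 as hydrogen does.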